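Difluoromethoxy to trifluoromethoxy: working notes on the series

This account rests on a few compounds, and the source may have more. Where it says the series, first, only, none or still open, it means among the compounds named here.

- compound 1 `OC[C@H]1O[C@@H](n2cnc3c(NCc4ccccc4F)ncnc32)[C@H](O)[C@@H]1O`: 4600 nM
- compound 2 `OC[C@H]1O[C@@H](n2cnc3c(NCc4ccccc4OC(F)F)ncnc32)[C@H](O)[C@@H]1O`: "not determined" (no result reported)

The series is read in a functional assay on CCRF-CEM cells (Homo sapiens) for antiproliferative activity, with a stated time of 72 h; on this read-out lower numbers stand for stronger inhibition and higher numbers for weaker inhibition. There, compound 2 stands without a number, its entry being "not determined" (no result reported). It therefore cannot be ranked against anything, and the only figure available is that of compound 1 at 4600 nM. Going by the values given here, no step between measured compounds exists either.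

Compound 3 `OC[C@H]1O[C@@H](n2cnc3c(NCc4ccccc4OC(F)(F)F)ncnc32)[C@H](O)[C@@H]1O` is still to be measured. The structural change leading to it is fluoro in place of hydrogen on a saturated chain carbon bound to two fluorine atoms and an oxygen on an aromatic ring, that is, difluoromethoxy to trifluoromethoxy.

With no number on the starting side, no direction can be argued for this change in this assay. The expectation is a result no further from compound 1 at 4600 nM than a modest step, possibly none beyond the scatter, and with weak activity remaining likely. For compound 3 the expected value is 5000 nM, with an estimated range from 1500 nM to 15000 nM.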

Compound 3, half-maximal inhibitory concentration: > 166000 nM
Compound 3 gave a limit, no number; the forecaster's own chance of this, stated with the estimate: 25%; middle value at least 33-fold (1.52 log units) away from the limit.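

In this assay, compound 3 reads only as a limit of the assay, not as a number: the limit of > 166000 nM in this assay, at which 1 of the 3 values shown sits. Going by these compounds alone, the group on this aromatic carbon therefore has a clear bearing on the read-out: trifluoromethoxy in place of fluoro gives an at least 36-fold higher number from compound 1 to compound 3 (1.55 log units; beyond the scatter), the first step of any size, where compound 1 alone offered a single figure with nothing to set against it. The step from compound 2 to compound 3 cannot be read, as compound 2 carries no number, so the change from difluoromethoxy to trifluoromethoxy remains without a measured effect, and the shift seen here belongs to the whole exchange of fluoro for trifluoromethoxy, not to one added fluorine.

Still open, as far as these compounds go, is how much of that shift goes with the oxygen link and how much with the fluorines on the chain carbon, and a number for compound 2 would begin to separate the two. A plain methoxy group, a chloro group or an amine on the same aromatic carbon would show whether the weak value of compound 1 can be improved at all from this place.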